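The source may report more compounds than this note shows. Statements on the series, on what has been measured and on what is new or still open speak of the compounds shown alone.

Measured so far:
compound 1 `Cc1c(C)c2c(c(C)c1OC(=O)CCC(=O)NC1CC(C)(C)N([O])C(C)(C)C1)CC[C@@](C)(CCC[C@H](C)CCC[C@H](C)CCCC(C)C)O2` in a toxicity assay on cells (Cricetulus griseus) for cytotoxicity, read by MTT assay, with a stated time of 72 h; a higher number here means a weaker inhibitor, a lower number a stronger inhibitor: > 300000 nM
compound 2 `CC1(C)CC(NC(=O)CCC(=O)O)C(C)(C)N1[O]` in this assay: > 300000 nM

The value for compound 1 is a limit of this assay and not a number. The value for compound 2 is likewise only a limit. Compound 1 thus stands at the limit of > 300000 nM in this assay, at which 2 of the 2 values shown sit, and no ordering between the two measured compounds can be read from this.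

Compound 3 `Cc1c(C)c2c(c(C)c1OC(=O)CCC(=O)NCC1CC(C)(C)N([O])C1(C)C)CC[C@@](C)(CCC[C@H](C)CCC[C@H](C)CCCC(C)C)O2` is not yet measured in this assay. It differs from compound 1 by a group of 11 heavy atoms (9 carbon, 1 nitrogen, 1 oxygen; one five-membered non-aromatic ring with 1 hetero atom) in place of a group of 11 heavy atoms (9 carbon, 1 nitrogen, 1 oxygen; one six-membered non-aromatic ring with 1 hetero atom), on an amide-type nitrogen. For the measured compounds named here, no measured step is available; a step from compound 1 to compound 3 in this assay is expected to stay within the scatter, because compound 1 sits at the limit of > 300000 nM in this assay, at which 2 of the 2 values shown sit. Compound 3 is expected to give about 400000 nM, in the range 150000 nM to 1200000 nM. The expected step is a step that the limit leaves unreadable from compound 1 to compound 3.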

Compound 3, half-maximal inhibitory concentration: > 300000 nM
Compound 3: only a limit was reported; the forecaster's own chance of this, stated with the estimate: 85%; the middle value is on the limit's open side.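

In this assay, for the compounds shown here, compound 1 and compound 3 both stand as limits and not numbers, and no step between them can be read. The compounds shown leave open at what concentration, if any, compound 1, compound 2 or compound 3 would reach half-maximal inhibition.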